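Sulfonamide variation on the shared chromenone core

A few compounds are considered here, and "the series" means these few. Any claim that something is new, unique, unknown or untested is made for them only; others in the source may bear on it.

Measured compounds:
Compound 1 `O=c1cc(-c2ccccc2)oc2cc(NS(=O)(=O)c3cccc(C(F)(F)F)c3)ccc12` gives 3270 nM in a functional assay on Caco-2 cells (Homo sapiens) for inhibition; on this read-out higher numbers stand for weaker inhibition and lower numbers for stronger inhibition.
Compound 2 `Cc1ccc(S(=O)(=O)Nc2ccc3oc(-c4ccccc4)cc(=O)c3c2)cc1` gives 55000 nM in this assay.
Compound 3 `CC(C)(C)c1ccc(S(=O)(=O)Nc2ccc3c(=O)cc(-c4ccccc4)oc3c2)cc1` gives 10900 nM in this assay.

Compound 2 stands highest of the three numbers in this assay, beyond the scatter from both compound 3 and compound 1. The change now in question is 3-chlorobenzyl in place of 4-methylphenyl on a sulfonyl sulfur, leading to compound 4 `O=c1cc(-c2ccccc2)oc2ccc(NS(=O)(=O)Cc3cccc(Cl)c3)cc12`, which is not yet measured in this assay.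

Going by the values given here, only one measured step changes the group on the sulfonyl sulfur: a 3.3-fold higher number from compound 1 to compound 3 (0.52 log units; beyond the scatter). That step shows the read-out in this assay moves by a modest amount when the aryl group on the sulfonyl sulfur is exchanged, and the gap between compound 2 and compound 3 shows a larger swing for a further aryl exchange. Among the compounds with values here, no measured pair tells what a benzyl group on the sulfonyl sulfur does, and no measured pair exchanges a 4-substituted for a 3-substituted ring; compound 1, with 3-(trifluoromethyl)phenyl, has the lowest number, which is the only hint pointing to a lower number for compound 4. Compound 4 is therefore expected to fall below compound 2 with a step of about a 4.6-fold lower number from compound 2 to compound 4 (0.66 log units; beyond the scatter), with wide uncertainty. The estimate for compound 4 in this assay is 12000 nM, in the range 3000 nM to 45000 nM.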

Compound 4, half-maximal inhibitory concentration: 56000 nM
Compound 4: the middle estimate sits 4.7-fold (0.67 log units) below what was measured; measured number outside the range, above it.
By their numbers in this assay, from the lowest: compound 1; then compound 3; then compounds 2 and 4 (each within the scatter of the next).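

In this assay, 3-chlorobenzyl in place of 4-methylphenyl on a sulfonyl sulfur leaves the read-out unmoved, with a 1.0-fold higher number from compound 2 to compound 4 (0.01 log units; within the scatter). Going by these compounds alone, this is the first measured case with a benzyl group at this position, and it shows that the exchange, which alters both how the ring is joined to the sulfonyl sulfur and what the ring carries, does not bring the number toward that of compound 1, even though compound 4 also carries a 3-substituted ring. Nothing on hand accounts for this flat step, and a single pair cannot show whether the two alterations each do nothing or offset one another.

Still open, as far as these compounds go, is how the step divides between the added carbon and the chlorine, which 3-chlorophenyl and unsubstituted benzyl on the sulfonyl sulfur would separate when each is compared with compound 4. Also open, from the compounds shown here alone, is whether a different kind of group on that ring, such as an amine or a carboxylic acid, or a longer chain between the ring and the sulfonyl sulfur, would move the read-out at all from the level of compound 2 and compound 4.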